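The compounds below may be only part of what the source reports. "The series", "measured", "known", "first", "only" and "open" are said of these compounds alone.

In a functional assay on HUVEC cells (Homo sapiens) for inhibition (on this read-out lower numbers stand for stronger inhibition and higher numbers for weaker inhibition), three compounds built on one shared core have been measured. Compound 1 (`COc1cc(/C=C/C(=O)c2cccc(NC(=O)c3cccs3)c2)ccc1O`) gives 0.38 ug/mL, compound 2 (`COc1cc(/C=C/C(=O)c2cccc(N)c2)ccc1O`) gives 2.87 ug/mL, and compound 3 (`COc1cc(/C=C/C(=O)c2cccc(NC(=O)c3ccc(Cl)c(Cl)c3)c2)ccc1O`) gives 2.97 ug/mL. Compound 3 thus sits within the scatter of compound 2, and both show clearly weaker inhibition than compound 1.

Compound 4 (`COc1cc(/C=C/C(=O)c2cccc(NC(=O)C(C)C)c2)ccc1O`) has isopropyl in place of 3,4-dichlorophenyl on a carbonyl carbon. Among the measured compounds shown here, three measured steps bear on this change. The group on that carbonyl carbon can matter, as seen in a 7.8-fold higher number from compound 1 to compound 3 (0.89 log units; beyond the scatter). Removing the thiophen-2-yl carbonyl also counts, with a 7.6-fold higher number from compound 1 to compound 2 (0.88 log units; beyond the scatter). Yet the (3,4-dichlorophenyl)carbonyl makes no difference against hydrogen, with a 1.0-fold higher number from compound 2 to compound 3 (0.01 log units; within the scatter).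

For the measured compounds named here, no measured compound carries isopropyl, so only one thiophen-2-yl example points to a stronger result. A step beyond the scatter is therefore not expected in this assay, only a lean toward a lower number. The expected change is a 1.9-fold lower number from compound 3 to compound 4 (0.27 log units; within the scatter). Compound 4 is estimated at 1.6 ug/mL, with an expected range of 0.4 ug/mL to 5 ug/mL.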

Compound 4, half-maximal inhibitory concentration: 1.44 ug/mL
Beside the measured number, compound 4's estimate is 1.1-fold (0.05 log units) above it; the range from low to high includes it.
By their numbers in this assay, from the lowest: compound 1; then compounds 4, 2 and 3 (each within the scatter of the next, the first and the last beyond it).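

In this assay, the group on the carbonyl carbon proves able to move the number without thiophen-2-yl: isopropyl in place of 3,4-dichlorophenyl gives a 2.1-fold lower number from compound 3 to compound 4 (0.31 log units; beyond the scatter), a modest step that replaces a ring with a group that has none. Measured against hydrogen on the nitrogen, however, isopropylcarbonyl gives a 2.0-fold lower number from compound 2 to compound 4 (0.30 log units; within the scatter), so neither of these two acyl groups separates from hydrogen. Thiophen-2-yl stays apart from isopropyl, with a 3.8-fold higher number from compound 1 to compound 4 (0.58 log units; beyond the scatter), leaving compound 1 alone beyond the scatter of compounds 2 and 4.

Nothing measured here explains these differences. From the compounds shown here alone, it remains open whether furan-2-yl, or a longer chain such as n-butyl, on that carbonyl carbon would come close to compound 1.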